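This account rests on a few compounds, and the source may have more. Where it says the series, first, only, none or still open, it means among the compounds named here.

- Compound 1 `O=c1c(C2CC2)cc(-c2ccc(F)nc2F)nn1Cc1ccc(Cl)cc1`: 39800 nM
- Compound 2 `O=c1c(CO)cc(-c2ccc(F)nc2F)nn1Cc1ccc(Cl)cc1`: > 100000 nM, a limit
- Compound 3 `COCCNc1nc(F)c(-c2nn(Cc3ccc(C#N)cc3)c(=O)c3ccccc23)cc1Cl`: > 100000 nM, a limit

All three values come from an ADME assay on HepG2 2.2.15 cells (Homo sapiens) for cytotoxicity, read by MTT assay, with a stated time of 8 days; a higher number here means that more compound is tolerated, a lower number that less compound is tolerated. Compound 2 stands at the limit of > 100000 nM in this assay, at which 2 of the 3 values shown sit, so its entry is a limit and not a number. The next structure is compound 4 `COC(=O)c1cc(-c2ccc(F)nc2F)nn(Cc2ccc(Cl)cc2)c1=O`, which carries methoxycarbonyl in place of hydroxymethyl on an aromatic carbon, opposite the ring nitrogen: methoxycarbonyl in place of hydroxymethyl on an aromatic carbon. One measured change bears on this carbon, hydroxymethyl in place of cyclopropyl, and it gave an at least 2.5-fold higher number from compound 1 to compound 2 (0.40 log units; beyond the scatter). That step is beyond the scatter and at least modest. Compound 3 has a different core and lacks this substitution, so it offers no direct guide. On that single step, a modest move to a lower number in this assay is expected, although a result that stays at the limit remains possible. For compound 4 the estimated value is 70000 nM, within an expected range from 25000 nM to 130000 nM. This estimate means an expected at least 1.4-fold lower number from compound 2 to compound 4 (0.15 log units; that floor lies within the scatter).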

Compound 4, half-maximal cytotoxic concentration: > 100000 nM
Compound 4 was reported as a limit (the forecaster's own chance of this, stated with the estimate: 45%); at least 1.4-fold (0.15 log units) between middle value and limit.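

Methoxycarbonyl in place of cyclopropyl on this aromatic carbon, opposite the ring nitrogen, gives an at least 2.5-fold higher number from compound 1 to compound 4 (0.40 log units; beyond the scatter) in this assay. This is a second replacement of cyclopropyl that moves the same way as hydroxymethyl did, which gave an at least 2.5-fold higher number from compound 1 to compound 2 (0.40 log units; beyond the scatter). The entry for compound 4 is also a limit, so the step from hydroxymethyl to methoxycarbonyl cannot be read and the two groups cannot be ordered: the limit of > 100000 nM in this assay, at which 3 of the 4 values shown sit.

Among the compounds shown at this carbon, only compound 1, with cyclopropyl, gives a number rather than a limit, at 39800 nM. As far as these compounds go, whether another carbon-linked ring such as cyclobutyl would also give a number remains open, as does whether an amine or a carboxylic acid at this carbon would stay at the limit.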